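The source may report more compounds than this note shows. Statements on the series, on what has been measured and on what is new or still open speak of the compounds shown alone.

Compound 1 `Cc1cccc(Cn2cc(CNC(=O)c3cnc(Nc4ccc(C#N)cc4)cc3Oc3c(C)cc(C)cc3C)nn2)c1` was tested in an ADME assay on MT4 cells (Homo sapiens) for cytotoxicity, read by MTT assay, with a stated time of 5 days (a higher number here means that more compound is tolerated, a lower number that less compound is tolerated), where compound 1 gives 114000 nM. Compound 2 `Cc1cc(C)c(Oc2cc(Nc3ccc(C#N)cc3)ncc2C(=O)NCc2cn(Cc3ccccc3Cl)nn2)c(C)c1` differs from it by a 2-chlorophenyl in place of a 3-methylphenyl on a saturated chain carbon bound to an aromatic nitrogen. In this assay compound 2 returns only a limit, >= 188000 nM, not a number. The step between them, an at least 1.6-fold higher number from compound 1 to compound 2 (0.21 log units; that floor lies within the scatter), has a floor that lies within the scatter, so it tells of no real movement. Compound 2 therefore stands at the limit of what was measured here, (the limit of >= 188000 nM in this assay, at which 1 of the 2 values shown sits), one of two values shown.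

Compound 3 `Cc1cc(C)c(Oc2cc(Nc3ccc(C#N)cc3)ncc2C(=O)NCc2cn(Cc3cccc([N+](=O)[O-])c3)nn2)c(C)c1` is the next member and has not been measured. Its difference from compound 2 is 3-nitrophenyl in place of 2-chlorophenyl on a saturated chain carbon bound to an aromatic nitrogen. Among the compounds with values here, the only measured step at that same place is an at least 1.6-fold higher number from compound 1 to compound 2 (0.21 log units; that floor lies within the scatter), and it gave no change beyond the scatter. With only that to go on, compound 3 is expected to sit near the limit as well, at an estimated 180000 nM with a range from 90000 nM to 400000 nM. The step of an at least 1.0-fold lower number from compound 2 to compound 3 (0.01 log units; that floor lies within the scatter) is accordingly expected to stay within the scatter, with a fair chance that the assay again reports only a limit.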

Compound 3, half-maximal cytotoxic concentration: >= 156000 nM
Compound 3: a limit, no number; the forecaster's own chance of this, stated with the estimate: 55%; the middle value does not contradict the limit.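

In this assay, the place on a saturated chain carbon bound to an aromatic nitrogen now carries a third substituted phenyl, and 3-nitrophenyl, with its 2 hydrogen-bond acceptors where 2-chlorophenyl has 0, again produces no readable movement. Set against the methyl-bearing ring of compound 1, nitro in place of methyl on an aromatic carbon gives an at least 1.3-fold higher number from compound 1 to compound 3 (0.13 log units; that floor lies within the scatter), so a change at the ring itself also shows no real shift in how much compound is tolerated. Compound 2 and compound 3 both return only limits, and the step between them cannot be read.

From the compounds shown here alone, whether this place tolerates anything other than a substituted phenyl stays open, since an amine or a carboxylic acid on the benzyl ring, or a longer chain in place of the benzyl, could give a different result. Nor do the compounds shown tell where the actual half-maximal cytotoxic concentrations of compound 2 and compound 3 lie, so any real difference between the chlorine and nitro rings remains hidden behind their limits.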